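This account rests on a few compounds, and the source may have more. Where it says the series, first, only, none or still open, it means among the compounds named here.

In a functional assay on PC-3 cells (Homo sapiens) for antiproliferative activity, read by MTT assay, with a stated time of 48 h (a lower number here means a stronger inhibitor of growth, a higher number a weaker inhibitor of growth), compound 1 `COc1ccc(/C=C2\Cc3cc(OC)c(OC)c(OC)c3C2=O)cc1` gives > 10000 nM, which is a limit of the assay and not a number. For the measured compounds named here, compound 2 `COc1cc2c(cc1O)C(=O)/C(=C/c1ccc(OC)c(OC)c1OC)C2` gives 3140 nM, the only actual number so far. Compound 3 `COc1cc2c(cc1OC)C(=O)/C(=C/c1ccc(OC)c(OC)c1OC)C2` differs from compound 2 in one place, hydroxy to methoxy: methyl in place of hydrogen on an oxygen on an aromatic ring. Going by the values given here, no measured pair shows this change. In this assay, a small step toward weaker inhibition of growth is expected, hardly beyond the scatter. The estimated step is a 1.3-fold higher number from compound 2 to compound 3 (0.11 log units; within the scatter). The estimate for compound 3 is 4000 nM, with an expected range from 1300 nM to 10000 nM.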

Compound 3, concentration for 50% growth inhibition: > 10000 nM
Compound 3 ended at the assay's limit; the forecaster's own chance of this, stated with the estimate: 20%; middle value at least 2.5-fold (0.39 log units) from the limit.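

In this assay, methyl in place of hydrogen on this oxygen gives an at least 3.1-fold higher number from compound 2 to compound 3 (0.50 log units; beyond the scatter), so the free hydroxy group of compound 2 is tied to the only measurable growth inhibition shown. Compound 3 gives > 10000 nM, which is a limit of the assay and not a number. The true size of the step stays unknown because the comparison ends at that limit: the limit of > 10000 nM in this assay, at which 2 of the 3 values shown sit.

The compounds shown leave open whether the hydrogen itself is needed. An amine in place of the hydroxy group, or a longer chain such as ethyl on this oxygen, could answer that.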